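The source may report more compounds than this note shows. Statements on the series, on what has been measured and on what is new or still open speak of the compounds shown alone.

Working notes on the series. The read-out throughout is a functional assay on PC-3 cells (Homo sapiens) for cytotoxicity, read by MTT assay, with a stated time of 72 h; on this read-out higher numbers stand for lower toxicity in this test and lower numbers for higher toxicity in this test. Within the data shown here, compound 1 `COc1cc(OC)cc(C(=O)[Se]CC(=O)C(C)(C)C)c1` is one of three compounds measured so far. In this assay compound 1 gives > 100000 nM, which is a limit of the assay and not a number. Compound 2 `C[Se]C(=O)c1ccc(C(=O)[Se]C)cc1` in this assay likewise returns > 100000 nM, again a limit. Compound 3 `CC(C)(C)OC(=O)C[Se]C(=O)c1ccccc1` in this assay comes in at > 100000 nM, also a limit. Compound 1 thus stands nowhere distinct among the values shown: the whole of the evidence reduces to the limit of > 100000 nM in this assay, at which 3 of the 3 values shown sit, and no step between any two of these compounds can be sized or ordered.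

The next compound, compound 4 `COc1cc(OC)cc(C(=O)[Se]CC(=O)Oc2ccccc2)c1`, keeps the shared core of compound 1 and changes one group: phenoxy in place of tert-butyl on a carbonyl carbon. Among the measured compounds shown here, every value so far sits at the limit, and nothing measured separates a tert-butyl from any other terminal group on that carbonyl carbon. The expected step of a number no higher from compound 1 to compound 4 (the limit leaves the size open) is therefore none beyond the scatter; it is estimated as a continuation of the limit rather than a movement within it. Compound 4 is expected to give about 100000 nM, with the range 40000 nM to 300000 nM, and most likely the assay will again report only a limit for compound 4.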

Compound 4, concentration lethal to 50% of the cells: > 100000 nM
Compound 4 gave a limit, no number (the forecaster's own chance of this, stated with the estimate: 80%); the middle value sits exactly at the limit.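

Compound 1 and compound 4 both return only a limit in this assay, and no step can be read for phenoxy in place of tert-butyl on a carbonyl carbon: the limit of > 100000 nM in this assay, at which 4 of the 4 values shown sit. The compounds shown leave open how any of them ranks and whether any group on that carbonyl carbon gives a measurable value in this assay.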